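From 3-Fluorophenyl to 4-(Trifluoromethyl)phenyl

This account rests on a few compounds, and the source may have more. Where it says the series, first, only, none or still open, it means among the compounds named here.

- Compound 1 `COc1cccc(Cc2cc(-c3ccc(F)cc3)nn(CC(=O)Nc3ccc(F)cc3)c2=O)c1`: > 50000 nM, a limit
- Compound 2 `COc1ccc(Cc2cc(Cc3ccccc3)nn(CC(=O)Nc3ccc(Br)cc3)c2=O)cc1`: > 50000 nM, a limit
- Compound 3 `Cc1cc(Cc2cccc(F)c2)c(=O)n(CC(=O)Nc2ccc(Br)cc2)n1`: > 50000 nM, a limit

These results come from a functional assay on HL-60 cells (Homo sapiens), read by calcium flux; on this read-out higher numbers stand for an effect only at larger amounts of compound and lower numbers for an effect already at smaller amounts. Compound 3 gives > 50000 nM, which is a limit and not a number. It shares this position with the other two compounds: the limit of > 50000 nM in this assay, at which 3 of the 3 values shown sit.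

Compound 4 `Cc1cc(Cc2ccc(C(F)(F)F)cc2)c(=O)n(CC(=O)Nc2ccc(Br)cc2)n1` carries 4-(trifluoromethyl)phenyl in place of 3-fluorophenyl on a saturated chain carbon bound to an aromatic carbon. Within the data shown here, no measured pair here differs in only one place, so the size of a single change cannot be read directly from these compounds. In this assay, no step beyond the scatter is expected, in either direction. This expectation rests on compound 3 sitting with the others at the limit of > 50000 nM in this assay, at which 3 of the 3 values shown sit. The expected change is an at least 1.2-fold lower number from compound 3 to compound 4 (0.09 log units; that floor lies within the scatter). The estimate for compound 4 is 40000 nM, with an expected range from 10000 nM to 50000 nM.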

Compound 4, half-maximal effective concentration: > 50000 nM
Compound 4 gave a limit, no number (the forecaster's own chance of this, stated with the estimate: 65%); at least 1.2-fold (0.09 log units) between middle value and limit.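

Compound 3 and compound 4 both give a limit and not a number, and no step can be read between them. The compounds shown leave open whether 4-(trifluoromethyl)phenyl in place of 3-fluorophenyl changes the effect at all.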